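The compounds below may be only part of what the source reports. "The series", "measured", "known", "first", "only" and "open" are said of these compounds alone.

Measured in a functional assay on the whole organism (stomach) with Rattus norvegicus as the target; a lower number here means that less compound is needed, a higher number that more compound is needed for the effect:
- compound 1, `N#CNC(=N)NCCCn1nc(-c2ccccc2)ccc1=O`: gives > 100 mg/kg, which is a limit of the assay and not a number.
- compound 2, `CC/N=C(/NC#N)NCCCCCn1nc(-c2ccccc2)ccc1=O`: gives 100 mg/kg.
- compound 3, `C/N=C(/NC#N)NCCCCn1nc(-c2ccccc2)c(C)cc1=O`: gives > 100 mg/kg, again a limit of the assay.

Compound 1 therefore stands at the edge of what this assay reports: for compound 1 only a limit is known, with no number behind it, and (the limit of > 100 mg/kg in this assay, at which 2 of the 3 values shown sit). Of the three compounds shown, only compound 2 returns a number, and that number sits at the same value as the limit, so the series as a whole is clustered at the upper end of the dosing range. Within the data shown here, no pair of measured compounds differs in a single place, so no measured step is available to calibrate the change now considered.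

Compound 4, `CC/N=C(/NC#N)NCCCn1nc(-c2ccccc2)ccc1=O`, differs from compound 1 in one place: a group of 7 heavy atoms (4 carbon, 3 nitrogen; no ring) in place of a group of 5 heavy atoms (2 carbon, 3 nitrogen; no ring), on an amine nitrogen. The same entering group is present in compound 2, on a longer chain, where compound 2 gives a number at the edge of the range rather than a limit. Compound 3, with a related group, remains a limit. On that basis the step of a number no higher from compound 1 to compound 4 (the limit leaves the size open) is expected to be small, at most a move from the limit to a number close to it. Compound 4 is expected to give about 100 mg/kg in this assay. For compound 4 the range of this estimate is 40 mg/kg to 250 mg/kg.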

Compound 4, dose for half-maximal effect: 78.3 mg/kg
Compound 4: the middle estimate sits 1.3-fold (0.11 log units) above what was measured, and the stated range covers the measured number.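

In this assay compound 1 gives > 100 mg/kg, a limit of the assay and not a number. Among these compounds, putting the group of 7 heavy atoms in place of the group of 5 heavy atoms on the amine nitrogen gives the first step that can be read at this position: an at least 1.2-fold lower number from compound 1 to compound 4 (0.10 log units; that floor lies within the scatter). That step is only a floor, so the change is shown to yield a measurable number on this core, while the real size of the move stays unknown, and the assay limit still marks much of the series: the limit of > 100 mg/kg in this assay, at which 2 of the 4 values shown sit.

On these data alone, the value of compound 1 behind its limit remains open, and with it whether this change does more than the scatter in this assay. Also open, as far as these compounds go, is how a benzyl group on the same nitrogen, or an amide in place of the nitrile, would read.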